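This account rests on a few compounds, and the source may have more. Where it says the series, first, only, none or still open, it means among the compounds named here.

Measured so far:
- compound 1 `c1ccc(C2(c3cc(OCc4ccc5ccccc5n4)ccc3OCc3ccc4ccccc4n3)CCCC2)cc1`: 1080 nM
- compound 2 `COC(=O)COc1ccc(OCc2ccc3ccccc3n2)cc1C1(c2ccccc2)CCCCC1`: 200 nM

In a functional assay on blood (Homo sapiens) for inhibition (on this read-out higher numbers stand for weaker inhibition and lower numbers for stronger inhibition), compound 2 holds the lower of the two numbers at 200 nM, and its gap to compound 1 lies beyond the scatter. Compound 3 `c1ccc(C2(c3cc(OCc4ccc5ccccc5n4)ccc3OCc3ccc4ccccc4n3)CCCCC2)cc1` is not yet measured. It differs from compound 2 by quinolin-2-yl in place of methoxycarbonyl on a saturated chain carbon bound to an oxygen on an aromatic ring, with quinolin-2-yl in place of methoxycarbonyl on a saturated chain carbon bound to an oxygen on an aromatic ring. For the measured compounds named here, no step between measured compounds isolates this change, and compound 1 differs from compound 2 in more than one place. Still, compound 1 also carries (quinolin-2-yl)methoxy and gives 1080 nM, so a shift to a higher number in this assay, beyond the scatter, is expected. The expected change is a 4.0-fold higher number from compound 2 to compound 3 (0.60 log units; beyond the scatter). For compound 3 the estimated value is 800 nM, with an expected range of 300 nM to 2200 nM.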

Compound 3, half-maximal inhibitory concentration: 3000 nM
Compound 3: middle estimate off by 3.8-fold (0.57 log units), on the low side; the measured number lies above the stated range.
By their numbers in this assay, from the lowest: compound 2; then compound 1; then compound 3.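

In this assay, the exchange at the saturated chain carbon bound to an oxygen on an aromatic ring can now be read on its own: quinolin-2-yl in place of methoxycarbonyl gives a large step (a 15-fold higher number from compound 2 to compound 3 (1.18 log units; beyond the scatter)). The group on the aromatic carbon also matters, though less, as 1-phenylcyclohexyl in place of 1-phenylcyclopentyl gives a modest step (a 2.8-fold higher number from compound 1 to compound 3 (0.44 log units; beyond the scatter)) with both (quinolin-2-yl)methoxy groups kept. No data shown here account for either step.

Going by these compounds, whether methoxycarbonyl gives a similar step when paired with 1-phenylcyclopentyl remains open, as does the effect of a carboxylic acid, an amide or a longer chain at the same chain carbon. The response to 1-phenylcyclobutyl on the aromatic carbon is also unknown.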